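From Methyl to Benzyloxy on a Shared Core

The source may hold more compounds than are shown below. What is called first, only, known or untested is meant among the compounds shown, and "the series" means these compounds.

Of the compounds shown here, three built on one shared core have been tested in a functional assay on MCF7 cells (Homo sapiens) for antiproliferative activity, read by MTT assay, with a stated time of 48 h; a higher number here means a weaker inhibitor, a lower number a stronger inhibitor. Compound 1 `CC(=O)N1N=C(c2ccc3ccccc3c2)OC1c1ccc(F)cc1`, which carries fluoro, gives 3.02 ug/mL. Compound 2 `CC(=O)N1N=C(c2ccc3ccccc3c2)OC1c1ccc([N+](=O)[O-])cc1`, which carries nitro, gives 7.59 ug/mL. Compound 3 `CC(=O)N1N=C(c2ccc3ccccc3c2)OC1c1ccc(C)cc1`, which carries methyl, gives 2.9 ug/mL. Compound 3 therefore sits level with compound 1 at the stronger end of this small set, and both lie clearly apart from compound 2.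

The next compound, compound 4 `CC(=O)N1N=C(c2ccc3ccccc3c2)OC1c1ccc(OCc2ccccc2)cc1`, puts benzyloxy in place of the methyl of compound 3: benzyloxy in place of methyl on an aromatic carbon.

Three measured swaps at this same place offer a guide. Exchanging fluoro for methyl made no real difference, with a 1.0-fold lower number from compound 1 to compound 3 (0.02 log units; within the scatter). Bringing in nitro had a modest cost, with a 2.5-fold higher number from compound 1 to compound 2 (0.40 log units; beyond the scatter), and removing it gave a modest gain, with a 2.6-fold lower number from compound 2 to compound 3 (0.42 log units; beyond the scatter). So changes here have been small so far, but none of them added a ring, which makes them only a loose guide for benzyloxy.

A small shift toward a weaker result is the expectation, with an estimated 1.4-fold higher number from compound 3 to compound 4 (0.14 log units; within the scatter). Compound 4 is expected to give about 4 ug/mL, within an estimated range of 1.7 ug/mL to 9.5 ug/mL.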

Compound 4, half-maximal inhibitory concentration: 5.49 ug/mL
Compound 4: the middle estimate sits 1.4-fold (0.14 log units) below what was measured; the range from low to high includes it.
By their numbers in this assay, from the lowest: compounds 3, 1, 4 and 2 (each within the scatter of the next, the first and the last beyond it).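

Benzyloxy brings a ring and 8 heavy atoms to a place that has so far held only small groups, yet in this assay replacing the single heavy atom of methyl gives a 1.9-fold higher number from compound 3 to compound 4 (0.28 log units; within the scatter). The other two comparisons also stay inside the usual spread of repeat measurements, with a 1.8-fold higher number from compound 1 to compound 4 (0.26 log units; within the scatter) and a 1.4-fold lower number from compound 2 to compound 4 (0.14 log units; within the scatter), so compound 4 cannot be told apart from any of the three earlier compounds, even though compound 2 and compound 3 are separated beyond the scatter. A much larger group with an added aromatic ring can therefore sit at this position on the shared core without a change this assay can resolve, although no measured information on these compounds explains this result.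

The compounds shown leave open how a group of a different kind, such as an amine or a carboxylic acid, would behave at this place. They also cannot separate the contribution of the oxygen from that of the added ring in benzyloxy, a question that methoxy and a longer chain ending in a phenyl ring could help to answer.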